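Aryl variation in the semicarbazide series: nitro to hydroxy

The source may hold more compounds than are shown below. What is called first, only, known or untested is meant among the compounds shown, and "the series" means these compounds.

Compound 3 `CC(C)=CC/C=C(/C)C/C=N/NC(=O)Nc1nnc(-c2ccc([N+](=O)[O-])cc2)o1` gives 300 mg/kg in a functional assay on the whole organism (strain Swiss albino) with Mus musculus as the target, with a stated time of 4 h; a higher number here means that more compound is needed for the effect, a lower number that less compound is needed. Among the measured compounds shown here, compound 1 `C=C(C)[C@@H]1CC=C(C)/C(=N/NC(=O)Nc2nnc(-c3ccc(OC)cc3)o2)C1` gives 300 mg/kg in this assay, and compound 2 `C=C(C)[C@@H]1CC=C(C)/C(=N/NC(=O)Nc2nnc(-c3cccc(O)c3)o2)C1` gives 300 mg/kg in this assay; compound 3 thus stands level with both, within the scatter, and no compound of the three can be set apart from the others. For the measured compounds named here, the only step measured so far, no change at the digits printed from compound 1 to compound 2 (within the scatter), shows no change within the scatter for 3-hydroxyphenyl in place of 4-methoxyphenyl, and its two compounds sit at the same minimum effective dose as compound 3. Compound 4 `CC(C)=CC/C=C(/C)C/C=N/NC(=O)Nc1nnc(-c2ccc(O)cc2)o1` differs from compound 3 by hydroxy in place of nitro on an aromatic carbon. Going by the values given here, no measured step touches a nitro group, so the exchange of hydroxy for nitro has no direct precedent here; the one aryl change on record left the dose unchanged. The expected step is one within the scatter, no change at the digits printed from compound 3 to compound 4 (within the scatter). Compound 4 is expected to give 300 mg/kg, with a range from 150 mg/kg to 600 mg/kg.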

Compound 4, minimum effective dose: 300 mg/kg
Beside the measured number, compound 4's estimate shows no gap at the digits printed; the measured number falls inside the stated range.
By their numbers in this assay, from the lowest: compounds 1, 2, 3 and 4 (each within the scatter of the next).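

Among the compounds shown here, the step of no change at the digits printed from compound 3 to compound 4 (within the scatter) in this assay is the first measured change of the group on this aromatic carbon, para to a large group, with the position itself held constant. Nitro leaves and hydroxy enters, bringing in a hydrogen-bond donor, and the minimum effective dose does not move at the digits printed, so this position has so far tolerated both groups in this series. The data offer no independent measurement that could account for this flat result.

Going by these compounds, whether an amine or a carboxylic acid on the same aromatic carbon would shift the dose remains open. With all the compounds shown at one value, it is also open whether any change at this position can separate compounds in this assay.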